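The compounds below may be only part of what the source reports. "The series", "measured", "known", "first", "only" and "open" are said of these compounds alone.

Measured in a functional assay on HL-60 cells (Homo sapiens) for antiproliferative activity, read by MTT assay, with a stated time of 48 h; a lower number here means a stronger inhibitor, a higher number a weaker inhibitor:
- Compound 1 `CC(C)=CCC[C@]1(C)/C=C/[C@@H](OC(=O)C=C(C)C)[C@](C)(O)/C=C/C(=O)/C(C(=O)O)=C\C1`: > 10000 nM
- Compound 2 `CSC(=S)OC/C1=C/C[C@](C)(CCC=C(C)C)/C=C/[C@@H](OC(=O)C=C(C)C)[C@](C)(O)/C=C/C1=O`: 180 nM

The entry for compound 1 is a limit of the assay, not a number. For the measured compounds named here, compound 2 therefore holds the only true number so far, and the one measured step, an at least 55-fold lower number from compound 1 to compound 2 (1.74 log units; beyond the scatter), is large and beyond the scatter. Compound 3 `CC(C)=CCC[C@]1(C)/C=C/[C@@H](OC(=O)C=C(C)C)[C@](C)(O)/C=C/C(=O)/C(C(=O)N(C)C)=C\C1` changes that same double-bonded ring carbon: a group of 5 heavy atoms (3 carbon, 1 nitrogen, 1 oxygen; no ring) in place of a group of 6 heavy atoms (3 carbon, 1 oxygen, 2 sulfur; no ring), on a double-bonded ring carbon. That step shows this place matters but does not rank the new group, so a moderate rise towards weaker inhibition in this assay is expected, namely an 8.3-fold higher number from compound 2 to compound 3 (0.92 log units; beyond the scatter). The estimate for compound 3 is 1500 nM, with an expected range of 250 nM to 9000 nM.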

Compound 3, half-maximal inhibitory concentration: 3340 nM
Beside the measured number, compound 3's estimate is 2.2-fold (0.35 log units) below it; the range from low to high includes it.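

With dimethylcarbamoyl on this double-bonded ring carbon, this assay shows a 19-fold higher number from compound 2 to compound 3 (1.27 log units; beyond the scatter), so the sulfur-containing group of compound 2 remains clearly ahead of this amide. Dimethylamino in place of hydroxy on the carbonyl carbon gives an at least 2.9-fold lower number from compound 1 to compound 3 (0.47 log units; beyond the scatter), so changing only part of the group here also moves the number. That step has no exact size, since it starts from a limit: the limit of > 10000 nM in this assay, at which 1 of the 3 values shown sits.

Which part of the group in compound 2 accounts for its lower number stays open. So does how a methyl ester or a primary amide would read at this carbon.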